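The source may report more compounds than this note shows. Statements on the series, on what has been measured and on what is new or still open speak of the compounds shown alone.

Compound 1 `Cc1ccccc1OCC1=NCCO1` and compound 2 `Clc1ccccc1OCC1=NCCO1` share one core and differ only in the group on one aromatic carbon. In a functional assay on the whole organism for inhibition, with Rattus norvegicus as the target, read by paw edema, with a stated time of 30 min, at a dose of 20 mg/kg by the oral route (on this read-out higher numbers stand for a stronger effect at the one dose given and lower numbers for a weaker effect), compound 1 gives 3.1%, while compound 2 gives 13.7%. Going by the values given here, compound 2 thus stands highest of the two numbers measured so far, its only neighbour being compound 1, and the step of a number 10.6 percentage points higher from compound 1 to compound 2 (beyond the scatter) is modest.

Compound 3 `Fc1ccccc1OCC1=NCCO1` has not yet been measured. It differs from compound 2 in one place: fluoro in place of chloro on an aromatic carbon. Among the compounds with values here, the single measured step, with chloro in place of methyl at that same carbon, raised this assay by a modest amount. Within the data shown here, no measured step exchanges one halogen for another, so the direction of the present change cannot be read directly from the numbers at hand; both measured values are low, and the whole measured span is only slightly wider than the scatter.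

The expected step is therefore small, downward or within the scatter: a number 5.7 percentage points lower from compound 2 to compound 3 (within the scatter). Compound 3 is estimated at 8%, with a range from 0% to 20%.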

Compound 3, a percentage reported as inhibition, in the whole organism at one dose (the size of the read-out at that dose, not a potency): 20.6%
The estimate for compound 3 lay 12.6 percentage points below the measured number, and the stated range ends below it.
By their numbers in this assay, from the lowest: compound 1; then compounds 2 and 3 (each within the scatter of the next).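

In this assay, fluoro in place of chloro on this aromatic carbon gives a number 6.9 percentage points higher from compound 2 to compound 3 (within the scatter), so this read-out cannot tell the two halogens apart at this position. Fluoro in place of methyl gives a number 17.5 percentage points higher from compound 1 to compound 3 (beyond the scatter), which, alongside a number 10.6 percentage points higher from compound 1 to compound 2 (beyond the scatter), shows that among these three compounds both halogens, and not chloro alone, stand clear of the methyl group. The data offer no explanation of why the two halogens group together here or why methyl stands apart from them.

The compounds shown leave open whether this grouping extends to a larger halogen such as bromo, or to quite different groups on the same carbon, such as methoxy, nitrile or an amine. They also leave open what the same exchanges would do on other carbons of the ring, and how these compounds would compare across several doses, since a reading at one dose shows the size of the effect at that dose and not a potency.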